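Trifluoromethyl in Place of Chloro: Expected Cytotoxicity

The source may report more compounds than this note shows. Statements on the series, on what has been measured and on what is new or still open speak of the compounds shown alone.

Compound 1 `FC(F)(F)c1ccc(-c2nn(-c3ccccc3)cc2CNc2ccc(Cl)cc2)cc1` — 44000 nM
Compound 2 `Brc1ccc(NCc2cn(-c3ccccc3)nc2-c2ccccc2)cc1` — > 100000 nM

For the measured compounds named here, in an ADME assay on MDBK cells (Bos taurus) for cytotoxicity, read by MTT assay, with a stated time of 72 h (a lower number here means that less compound is tolerated, a higher number that more compound is tolerated), compound 1 gives 44000 nM, the only plain number in this small set. Compound 2 gives no number in this assay and sits at the limit of > 100000 nM in this assay, at which 1 of the 2 values shown sits. Compound 3 `FC(F)(F)c1ccc(NCc2cn(-c3ccccc3)nc2-c2ccc(C(F)(F)F)cc2)cc1` differs from compound 1 in one place: trifluoromethyl in place of chloro on an aromatic carbon. Going by the values given here, no measured step gauges such a change, so the expected move is a 1.5-fold lower number from compound 1 to compound 3 (0.17 log units; within the scatter), within the scatter or at most slightly toward less compound tolerated. Compound 3 is therefore expected to give 30000 nM in this assay, lying between 10000 nM and 100000 nM.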

Compound 3, half-maximal cytotoxic concentration: 26000 nM
Compound 3: middle estimate off by 1.2-fold (0.06 log units), on the high side, within the range that was stated.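

In this assay, trifluoromethyl in place of chloro on this aromatic carbon, para to a large group, gives a 1.7-fold lower number from compound 1 to compound 3 (0.23 log units; within the scatter). For the compounds shown here, this places a measured step at this position for the first time: exchanging 1 heavy atom for 4 leaves compound 1 and compound 3 indistinguishable in this read-out. Nothing in the evidence at hand bears on this result. The compounds shown leave open how an amine or a carboxylic acid would read at this position. They also leave open whether the same exchange would read alike on other members of the series.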